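A few compounds are considered here, and "the series" means these few. Any claim that something is new, unique, unknown or untested is made for them only; others in the source may bear on it.

The measured compounds:
compound 1, `CCCS(=O)(=O)Nc1ccc(F)c(C(=O)c2n[nH]c3ncc(-c4ccc(N)cc4)cc23)c1F`, which in an assay for binding affinity to dual specificity mitogen-activated protein kinase kinase 4 (Homo sapiens), read by KINOMEscan, tested at 10 nM (a lower number here means a stronger effect, a higher number a weaker effect of the compound at the concentration tested), gives 3.7%;
compound 2, `CCCS(=O)(=O)Nc1ccc(F)c(C(=O)c2n[nH]c3ncc(-c4ccc(S(N)(=O)=O)cc4)cc23)c1F`, which in this assay gives 5.1%.

For the measured compounds named here, compound 2 holds the higher of the two numbers, but its only neighbour, compound 1, sits a number 1.4 percentage points higher from compound 1 to compound 2 (within the scatter), so the two compounds cannot be told apart on this read-out.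

Compound 3, `CCCS(=O)(=O)Nc1ccc(F)c(C(=O)c2n[nH]c3ncc(-c4ccc(S(=O)(=O)NC(C)=O)cc4)cc23)c1F`, is the compound not yet measured. It differs from compound 2 in one place: acetyl in place of hydrogen on a sulfonamide nitrogen. Going by the values given here, only one measured step exists, a number 1.4 percentage points higher from compound 1 to compound 2 (within the scatter), and it changes the group on the aromatic carbon, not the sulfonamide nitrogen, so it bears on the new step only indirectly, by showing that the group at this end of the molecule has so far moved the number little. On that basis no step beyond the scatter is expected in this assay for compound 3, the estimated change being a number 1.9 percentage points higher from compound 2 to compound 3 (within the scatter). Compound 3 is therefore estimated at 7%, within a range from 2% to 20%.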

Compound 3, a percentage reported as activity, at one concentration (the size of the read-out at that concentration, not a potency): 0.5%
The estimate for compound 3 lay 6.5 percentage points above the measured number; measured number below the stated range.
By their numbers in this assay, from the lowest: compounds 3, 1 and 2 (each within the scatter of the next).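

In this assay, for the compounds shown here, acetyl on the sulfonamide nitrogen gives a number 4.6 percentage points lower from compound 2 to compound 3 (within the scatter), so this nitrogen, which the earlier compounds carried only with its hydrogens, takes a group of 3 heavy atoms with no step beyond the scatter. Set against the amino compound, the change gives a number 3.2 percentage points lower from compound 1 to compound 3 (within the scatter), which means that amino, sulfamoyl and acetylsulfamoyl on this aromatic carbon cannot be told apart on this read-out, and the tolerance seen so far now extends one bond further out from the ring. No measurement available here offers any explanation for this result.

The compounds shown leave open whether the same holds for other groups on the sulfonamide nitrogen, such as a simple methyl, a longer acyl chain like butanoyl, or a benzoyl, or for a carboxylic acid on the aromatic carbon in place of the sulfonamide. As far as these compounds go, since the read-out is taken at one concentration and is not a potency, it also remains open whether these three compounds would separate if compared by full concentration-response measurements.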